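The source may report more compounds than this note shows. Statements on the series, on what has been measured and on what is new or still open speak of the compounds shown alone.

Compounds measured so far:

Compound 1 `Cc1nc(N(C)C(=O)NC(=O)c2c(F)cccc2F)sc1C(=O)N/N=C/c1ccc(C(F)(F)F)cc1` is one of three. In a functional assay on HepG2 cells (Homo sapiens) for inhibition, read by MTT assay, with a stated time of 72 h (on this read-out higher numbers stand for weaker inhibition and lower numbers for stronger inhibition), compound 1 gives > 100 ug/mL, which is a limit of the assay and not a number.

Compound 2 `Cc1nc(N(C)C(=O)NC(=O)c2c(F)cccc2F)sc1C(=O)N/N=C/c1ccccc1C(F)(F)F` in this assay gives 1.11 ug/mL.

Compound 3 `COc1ccc(/C=N/NC(=O)c2sc(N(C)C(=O)NC(=O)c3c(F)cccc3F)nc2C)cc1` in this assay gives 22.7 ug/mL.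

Compound 2 therefore holds the lowest number among the values shown, with compound 3 the nearest at a 20-fold higher number from compound 2 to compound 3 (1.31 log units; beyond the scatter). Compound 4 `CN(C(=O)NC(=O)c1c(F)cccc1F)c1nc(C(F)(F)F)c(C(=O)N/N=C/c2ccccc2C(F)(F)F)s1` has not yet been measured. It differs from compound 2 in one place: trifluoromethyl in place of methyl on an aromatic carbon.

All three measured steps concern a different part of the molecule, the aryl group on the carbon with a double bond to nitrogen: an at least 90-fold lower number from compound 1 to compound 2 (1.95 log units; beyond the scatter), an at least 4.4-fold lower number from compound 1 to compound 3 (0.64 log units; beyond the scatter) and a 20-fold higher number from compound 2 to compound 3 (1.31 log units; beyond the scatter). Among the measured compounds shown here, none of them alters the group on the five-membered aromatic ring, so no measured step bears directly on the change from compound 2 to compound 4. Without a precedent for this position, the expectation is a step near to or within the scatter, with the direction uncertain, and the estimate is a 1.4-fold higher number from compound 2 to compound 4 (0.16 log units; within the scatter) in this assay. Compound 4 is thus expected to give about 1.6 ug/mL, with a likely range from 0.4 ug/mL to 7 ug/mL.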

Compound 4, half-maximal inhibitory concentration: 26.1 ug/mL
Compound 4: middle estimate off by 16-fold (1.21 log units), on the low side; measured number outside the range, above it.
By their numbers in this assay, from the lowest: compound 2; then compounds 3 and 4 (each within the scatter of the next). At a limit, above all of these: compound 1.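

In this assay, trifluoromethyl in place of methyl on the aromatic carbon next to the ring nitrogen gives a 24-fold higher number from compound 2 to compound 4 (1.37 log units; beyond the scatter), a large loss that compounds 1, 2 and 3 could not reveal, as all of them carry methyl there. The aryl group is therefore not the only part of this series that moves the number, and this small position on the five-membered aromatic ring also matters. The number for compound 4 is still a measured one and not a limit: the limit of > 100 ug/mL in this assay, at which 1 of the 4 values shown sits.

On these data alone, whether an ethyl chain, a chlorine atom or an amine at this position would keep the low number of compound 2 remains open. Also open, as far as these compounds go, is whether the same change would have a similar effect with 4-methoxyphenyl as the aryl group.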